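This account rests on a few compounds, and the source may have more. Where it says the series, first, only, none or still open, it means among the compounds named here.

Working notes on the series. Going by the values given here, compound 1 `Cc1ccc(CNC(=O)c2nn(-c3ccc(F)cc3)c(CC[C@@H](O)C[C@@H](O)CC(=O)O)c2C(C)C)cc1` is the only member with a number: in a functional assay on L6 cells (Rattus norvegicus) for inhibition (on this read-out higher numbers stand for weaker inhibition and lower numbers for stronger inhibition), compound 1 gives 800 nM. Among the compounds with values here, compound 2 `COc1ccc(CNC(=O)c2nn(-c3ccc(F)cc3)c(OC[C@@H](O)C[C@@H](O)CC(=O)O)c2C(C)C)cc1` shares the core and the amide but carries a different group on the amide nitrogen and an oxygen linker to the side chain; in this assay compound 2 is recorded as "not determined" (no result reported), so no number stands for it and no step between measured compounds can be drawn. Compound 3 `CC(C)c1c(C(=O)N(C)Cc2ccc(F)c(F)c2)nn(-c2ccc(F)cc2)c1OC[C@@H](O)C[C@@H](O)CC(=O)O` is the next member to be tested. How compound 3 differs from compound 2: (3,4-difluorobenzyl)(methyl)amino in place of (4-methoxybenzyl)amino on a carbonyl carbon. Within the data shown here, with no measured step for this kind of change anywhere, neither the direction nor the size of the shift in this assay from compound 2 to compound 3 can be inferred from the data, and the only anchor is compound 1 with 800 nM. On that basis the potency of compound 3 in this assay is estimated at 1000 nM, with a range from 200 nM to 5000 nM, an expectation resting on compound 1 alone.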

Compound 3, half-maximal inhibitory concentration: 4570 nM
For compound 3 the middle estimate is 4.6-fold (0.66 log units) below the measured one; low and high end bracket the measured number.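

No new step can be read from compound 3, which gives 4570 nM in this assay, since compound 2 has no number there and compound 1 differs from compound 3 in more than one place. The compounds shown leave open how replacing (4-methoxybenzyl)amino with (3,4-difluorobenzyl)(methyl)amino shifts potency. No supporting evidence bears on this result.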